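Extending the chain from compound 2 to compound 3

The source may report more compounds than this note shows. Statements on the series, on what has been measured and on what is new or still open speak of the compounds shown alone.

Measured so far:
compound 1 `Cc1cccc(Cc2nc(N)c3nn(-c4ccccc4)cc3n2)c1`: 11%
compound 2 `Nc1nc(Cc2ccc(Cl)cc2)nc2cn(-c3ccccc3)nc12`: 11%

In an assay on CHO cells for displacement of a labelled ligand from adenosine receptor A3 (Homo sapiens), read by scintillation counting, tested at 1 uM (on this read-out higher numbers stand for more inhibition at the one concentration tested (going by the name of the read-out) and lower numbers for less inhibition), compound 1 gives 11%, and compound 2 gives 11%. Among the compounds with values here, the one measured step, no change at the digits printed from compound 1 to compound 2 (within the scatter), shows that swapping one substituted ring for another on the saturated chain carbon bound to an aromatic carbon left the read-out where it was. Compound 2 therefore stands level with compound 1, and both sit low on this assay.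

Compound 3 `Nc1nc(CCc2ccccc2)nc2cn(-c3ccccc3)nc12` differs from compound 2 by benzyl in place of 4-chlorophenyl on a saturated chain carbon bound to an aromatic carbon. Within the data shown here, only the step from compound 1 to compound 2 bears on this change, and it was flat, so no step beyond the scatter is expected here either; the estimated step is a number 1 percentage points higher from compound 2 to compound 3 (within the scatter). Compound 3 is expected to give about 12% in this assay, with a range from 0% to 30%.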

Compound 3, a percentage reported as inhibition, at one concentration (the size of the read-out at that concentration, not a potency): 17%
The estimate for compound 3 lay 5 percentage points below the measured number; the range from low to high includes it.
By their numbers in this assay, from the lowest: compounds 1, 2 and 3 (each within the scatter of the next).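

In this assay, phenethyl in place of 4-chlorobenzyl gives a number 6 percentage points higher from compound 2 to compound 3 (within the scatter), and benzyl in place of 3-methylphenyl on a saturated chain carbon bound to an aromatic carbon gives a number 6 percentage points higher from compound 1 to compound 3 (within the scatter). So neither the longer link to the ring nor the absence of the chlorine or methyl group separates compound 3 from the earlier compounds, and all three remain low at the one concentration tested. No supporting measurement is available to explain this reading.

The compounds shown leave open whether a longer chain such as phenylpropyl, or an amine or a carboxylic acid on the ring, would lift the number clear of this low band. They also leave open how the read-out responds to changes elsewhere on the shared core.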